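This account rests on a few compounds, and the source may have more. Where it says the series, first, only, none or still open, it means among the compounds named here.

Measured in a functional assay on MCF7 cells (Homo sapiens) for inhibition, read by MTT assay, with a stated time of 48 h, tested at 10 uM (on this read-out higher numbers stand for more inhibition of growth at the one concentration tested and lower numbers for less inhibition of growth), the compounds read as follows.

- Compound 1 `Cc1oc2c([C@H]3CCN(C)C[C@H]3O)c(O)cc(O)c2c(=O)c1C(O)c1ccc([N+](=O)[O-])cc1`: 4%
- Compound 2 `Cc1oc2c([C@H]3CCN(C)C[C@H]3O)c(O)cc(O)c2c(=O)c1C(O)c1ccccc1Br`: 21%
- Compound 3 `Cc1oc2c([C@H]3CCN(C)C[C@H]3O)c(O)cc(O)c2c(=O)c1C(O)c1c(F)cccc1Cl`: 41%

Compound 3 stands highest of these three. Compound 4 `Cc1oc2c([C@H]3CCN(C)C[C@H]3O)c(O)cc(O)c2c(=O)c1C(O)c1cc(F)cc(F)c1` differs from it by 3,5-difluorophenyl in place of 2-chloro-6-fluorophenyl on a saturated chain carbon bound to an aromatic carbon and an oxygen on a saturated carbon. The change lies on a saturated chain carbon bound to an aromatic carbon and an oxygen on a saturated carbon. Among the compounds with values here, three measured steps bear on it, all at this place: a number 17 percentage points higher from compound 1 to compound 2 (beyond the scatter), a number 20 percentage points higher from compound 2 to compound 3 (beyond the scatter) and a number 37 percentage points higher from compound 1 to compound 3 (beyond the scatter). The first two are modest and the last is large. Within the data shown here, no measured compound carries 3,5-difluorophenyl, so nothing compares it directly. Compound 3 holds the top value, with a number 20 percentage points higher from compound 2 to compound 3 (beyond the scatter) as its nearest gap, so a modest fall is expected. The expected change is a number 18 percentage points lower from compound 3 to compound 4 (beyond the scatter). For compound 4 the estimated value is 23%, within an expected range of 6% to 43%.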

Compound 4, percent growth inhibition at one concentration: 25%
For compound 4 the middle estimate is 2 percentage points below the measured one; measured number inside the range.
By their numbers in this assay, from the lowest: compound 1; then compounds 2 and 4 (each within the scatter of the next); then compound 3.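

Within this assay, the change to 3,5-difluorophenyl gives (a number 16 percentage points lower from compound 3 to compound 4 (beyond the scatter)), so carrying two halogens on the ring does not alone preserve the top reading at this place. The 3,5-difluorophenyl and 2-bromophenyl groups cannot be separated (a number 4 percentage points higher from compound 2 to compound 4 (within the scatter)), while 3,5-difluorophenyl still reads above 4-nitrophenyl (a number 21 percentage points higher from compound 1 to compound 4 (beyond the scatter)). Nothing available explains these differences. Going by these compounds, how a plain phenyl, a pyridyl or a cyclohexyl group would read at this place remains open.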